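Methoxy in Place of Hydrogen on a Formamide Carbonyl

The compounds below may be only part of what the source reports. "The series", "measured", "known", "first", "only" and "open" are said of these compounds alone.

Compound 3 `O=CNC[C@H]1CN(c2ccc(-n3cc(-c4ccccn4)cn3)c(F)c2)C(=O)O1` is the least lipophilic of the three measured analogues: in a physicochemical assay for lipophilicity, read by HPLC, measured as octanol-water partition (on this read-out lower numbers stand for lower lipophilicity and higher numbers for higher lipophilicity), compound 3 gives 1.19. Compound 1 `CC(=O)OC[C@H]1CN(c2ccc(-n3cc(-c4ccccn4)cn3)c(F)c2)C(=O)O1` gives 2.09 and compound 2 `O=C1O[C@@H](CSc2cccs2)CN1c1ccc(-n2cc(-c3ccccn3)cn2)c(F)c1` gives 4.29. The measured steps were a number 0.90 log units lower from compound 1 to compound 3 (beyond the scatter), a number 2.20 log units higher from compound 1 to compound 2 (beyond the scatter) and a number 3.10 log units lower from compound 2 to compound 3 (beyond the scatter). Compound 4 `COC(=O)NC[C@H]1CN(c2ccc(-n3cc(-c4ccccn4)cn3)c(F)c2)C(=O)O1` differs from compound 3 by methoxy in place of hydrogen on a carbonyl carbon. Within the data shown here, none of the measured steps makes this exact change; the nearest, a number 0.90 log units lower from compound 1 to compound 3 (beyond the scatter), exchanged the whole group on the chain, whereas here only a small piece is added to the formyl carbon. A modest rise in this assay is therefore expected, well short of any measured step. The expected step is a number 0.41 log units higher from compound 3 to compound 4 (beyond the scatter). Compound 4 is estimated at 1.6, within a range from 1.2 to 2.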

Compound 4, partition coefficient: 2.03
The estimate for compound 4 lay 0.43 log units below the measured number; measured number outside the range, above it.
By their numbers in this assay, from the lowest: compound 3; then compounds 4 and 1 (each within the scatter of the next); then compound 2.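

Putting methoxy on this carbonyl carbon moves this assay clearly, with a number 0.84 log units higher from compound 3 to compound 4 (beyond the scatter) from just this small addition. The resulting (methoxycarbonyl)amino group sits level with acetoxy on the chain, with a number 0.06 log units lower from compound 1 to compound 4 (within the scatter) and no order between the two, while (thiophen-2-yl)sulfanyl stays far apart, with a number 2.26 log units lower from compound 2 to compound 4 (beyond the scatter) at this same place. No measurement available here explains these shifts.

As far as these compounds go, what remains open is whether ethoxy, with its longer chain, or an amine such as dimethylamino on the same carbonyl carbon would shift the number further, or in the other direction.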